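The source may hold more compounds than are shown below. What is called first, only, known or untested is meant among the compounds shown, and "the series" means these compounds.

Measured so far in an assay on microsomes from intestinal mucosa for inhibition of acyl-CoA:cholesterol acyltransferase (Oryctolagus cuniculus); on this read-out lower numbers stand for stronger inhibition and higher numbers for weaker inhibition:
compound 1, `CCCCCCCCCCCCCCCCS(=O)(=O)Nc1c(OC)cc(OC)cc1OC` — 690 nM
compound 2, `CCCCCCCC/C=C\CCCCCCCCNC(=O)Nc1c(C)cccc1C` — 160 nM
compound 3, `CCCCCCCCCCCCCCCCCCNC(=O)Nc1c(C)cccc1C` — 610 nM; 610 nM (2 entries)

Among the single values, compound 2 has the lowest number; compound 1 lies higher by a gap beyond the scatter, and compound 3 contributes two entries rather than one number. For the measured compounds named here, no two of these differ in a single place, so no one-point step is available from them.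

Compound 4, `CCCCCCCC/C=C\CCCCCCCCNC(=O)Nc1c(C)cccc1Cl`, has not yet been run in this assay. It differs from compound 2 as follows: chloro in place of methyl on an aromatic carbon. With no measured step of this kind in the set, the expectation is a change that stays within the scatter, in either direction.

For compound 4 the estimate is 200 nM with a range of 70 nM to 600 nM. The step this estimate implies, a 1.3-fold higher number from compound 2 to compound 4 (0.10 log units; within the scatter), is expected to stay within the scatter.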

Compound 4, half-maximal inhibitory concentration: 180 nM
Beside the measured number, compound 4's estimate is 1.1-fold (0.05 log units) above it, within the range that was stated.
By their numbers in this assay, from the lowest: compounds 2 and 4 (each within the scatter of the next); then compound 1.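

In this assay, for the compounds shown here, chloro in place of methyl on this aromatic carbon, ortho to a large group, gives the first one-point step (a 1.1-fold higher number from compound 2 to compound 4 (0.05 log units; within the scatter)). With the chain of compound 2 in place, this position therefore takes either group without a change beyond the scatter. No evidence at hand bears on the origin of this result.

Still open, going by these compounds, is how a bare hydrogen, a methoxy group or a tert-butyl group would read at this position. Also open, on these data alone, is whether the same exchange holds with the chain of compound 3.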